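Fluoro to nitro on compound 1

A few compounds are considered here, and "the series" means these few. Any claim that something is new, unique, unknown or untested is made for them only; others in the source may bear on it.

Compound 1 `CC(=O)c1nnn(-c2nc(Cl)nc(Cl)n2)c1NCc1ccc(F)cc1`: 0.34 mg/kg
Compound 2 `CC(=O)c1nnn(-c2nc(Cl)nc(Cl)n2)c1NCc1ccc(Cl)cc1`: 0.39 mg/kg
Compound 3 `CC(=O)c1nnn(-c2nc(Cl)nc(Cl)n2)c1NCc1cc(F)cc(F)c1`: 0.46 mg/kg
Compound 4 `CC(=O)c1nnn(-c2nc(Cl)nc(Cl)n2)c1NCc1ccc([N+](=O)[O-])cc1`: not yet measured

In a functional assay on the whole organism with Mus musculus as the target (on this read-out lower numbers stand for an effect already at smaller amounts and higher numbers for an effect only at larger amounts of compound), compound 1 gives 0.34 mg/kg. Its neighbours lie close by, and no order among the three can be read from these numbers. The next compound keeps the core of compound 1 and changes one group: nitro in place of fluoro on an aromatic carbon. In words, nitro takes the place of fluoro on an aromatic carbon, so 4-fluorophenyl becomes 4-nitrophenyl.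

The closest measured change is chloro in place of fluoro, a 1.1-fold higher number from compound 1 to compound 2 (0.06 log units; within the scatter). Moving to 3,5-difluorophenyl gave a 1.4-fold higher number from compound 1 to compound 3 (0.13 log units; within the scatter). Within the data shown here, neither step leaves the scatter, but no measured compound carries nitro, so they guide the expectation only indirectly. A step beyond the scatter is therefore not expected in this assay, though the range stays wide in both directions. The expected step is a 1.3-fold higher number from compound 1 to compound 4 (0.12 log units; within the scatter). For compound 4 the estimate is 0.45 mg/kg, with an expected range from 0.2 mg/kg to 1 mg/kg.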

Compound 4, dose for half-maximal effect: 0.27 mg/kg
Compound 4: the middle estimate sits 1.7-fold (0.22 log units) above what was measured, and the stated range covers the measured number.
By their numbers in this assay, from the lowest: compounds 4, 1, 2 and 3 (each within the scatter of the next).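

Nitro, with three heavy atoms and two hydrogen-bond acceptors, takes the place of a single fluorine para to a large group, and in this assay this gives a 1.3-fold lower number from compound 1 to compound 4 (0.10 log units; within the scatter) and stays within the scatter. The other two comparisons read the same way, with a 1.4-fold lower number from compound 2 to compound 4 (0.16 log units; within the scatter) for nitro in place of chloro and a 1.7-fold lower number from compound 3 to compound 4 (0.23 log units; within the scatter) for 4-nitrophenyl in place of 3,5-difluorophenyl, so the widest gap among these four compounds also stays within the scatter. Among these four compounds, then, a larger group carrying hydrogen-bond acceptors at this place does not separate itself from the halogens in this assay and leaves no order that can be read.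

Nothing at hand explains this result. As far as these compounds go, whether an amine, a carboxylic acid or a longer chain at this same place would leave the scatter remains open.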